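Methoxy to Nitro: Estimating Compound 4's Cytotoxicity

The source may report more compounds than this note shows. Statements on the series, on what has been measured and on what is new or still open speak of the compounds shown alone.

Measured so far in a functional assay on L1210 cells (Mus musculus) for cytotoxicity, with a stated time of 48 h; a higher number here means a weaker inhibitor, a lower number a stronger inhibitor:
compound 1 `O=Cc1c(-c2ccc(Cl)cc2)nc2sc(Cc3ccc(Cl)cc3)nn12` gives 15000 nM
compound 2 `O=Cc1c(-c2ccc(Br)cc2)nc2sc(Cc3ccc(Cl)cc3)nn12` gives 4600 nM
compound 3 `COc1ccc(-c2nc3sc(Cc4ccc(Cl)cc4)nn3c2C=O)cc1` gives 5300 nM

Compound 3 gives a lower number than compound 1, a 2.8-fold lower number from compound 1 to compound 3 (0.45 log units; beyond the scatter), and stands within the scatter of compound 2, a 1.2-fold higher number from compound 2 to compound 3 (0.06 log units; within the scatter). Compound 4 `O=Cc1c(-c2ccc([N+](=O)[O-])cc2)nc2sc(Cc3ccc(Cl)cc3)nn12` has not yet been measured; it differs from compound 3 in one place: nitro in place of methoxy on an aromatic carbon. Within the data shown here, the steps that bear on this are the earlier changes at the same place: a 3.3-fold lower number from compound 1 to compound 2 (0.51 log units; beyond the scatter) and a 2.8-fold lower number from compound 1 to compound 3 (0.45 log units; beyond the scatter), both modest, while the third lies within the scatter. A modest shift in either direction is therefore possible in this assay, but no step beyond the scatter is firmly expected. Compound 4 is estimated at 6000 nM, between 2000 nM and 20000 nM, meaning an expected step of a 1.1-fold higher number from compound 3 to compound 4 (0.05 log units; within the scatter).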

Compound 4, half-maximal inhibitory concentration: 15000 nM
Compound 4: middle estimate off by 2.5-fold (0.40 log units), on the low side; low and high end bracket the measured number.
By their numbers in this assay, from the lowest: compounds 2 and 3 (each within the scatter of the next); then compounds 1 and 4 (each within the scatter of the next).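

At this position, nitro does not match methoxy: in this assay the swap gives a 2.8-fold higher number from compound 3 to compound 4 (0.45 log units; beyond the scatter), and replacing bromo gives a 3.3-fold higher number from compound 2 to compound 4 (0.51 log units; beyond the scatter). Replacing chloro gives no change at the digits printed from compound 1 to compound 4 (within the scatter), so the four groups form two pairs, nitro with chloro and bromo with methoxy. Nothing measured here explains this split. The compounds shown leave open where an amine, a carboxylic acid or a longer chain in the same place would fall, and whether either pair would remain together with those groups.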